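Working notes: terminal aryl substituent, compounds 1 to 4

The source may report more compounds than this note shows. Statements on the series, on what has been measured and on what is new or still open speak of the compounds shown alone.

Compound 1 `O=C(O)CC/C=C\CO[C@H]1[C@@H](OCc2ccc(-c3ccccc3CO)cc2)CC[C@@H]1N1CCCCCC1` gives 12.6 nM in a functional assay for antagonist activity at thromboxane A2 receptor (Rattus norvegicus); a higher number here means weaker binding, a lower number tighter binding. Compound 2 `NC(=O)c1ccccc1-c1ccc(COC2CC[C@H](N3CCCCCC3)[C@H]2OC/C=C\CCC(=O)O)cc1` gives 15.9 nM in this assay. Compound 3 `O=C(O)CC/C=C\CO[C@H]1[C@@H](OCc2ccc(-c3ccccc3)cc2)CC[C@@H]1N1CCCCCC1` gives 39.8 nM in this assay.

Compound 2 stands second highest of the three numbers. Its nearest neighbour is compound 1, a difference within the scatter, so the two cannot be ordered. Compound 3 lies furthest away, with a higher number beyond the scatter.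

The next compound, compound 4 `O=C(O)CC/C=C\CO[C@H]1C(OCc2ccc(-c3ccccc3O)cc2)CC[C@@H]1N1CCCCCC1`, has not yet been measured. It differs from compound 2 in one place: hydroxy in place of carbamoyl on an aromatic carbon.

Within the data shown here, only one measured step bears on this position of the terminal ring. Removing the hydroxymethyl group gave a 3.2-fold higher number from compound 1 to compound 3 (0.50 log units; beyond the scatter), a modest loss. Compound 1 and compound 2 carry different groups at that position, each with one hydrogen-bond donor and one hydrogen-bond acceptor, and their values sit within the scatter of each other. The incoming hydroxy group also brings one donor and one acceptor. The expectation is therefore a step near zero, within the scatter, in this assay.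

Compound 4 is estimated at 20 nM, with a range of 8 nM to 50 nM, which means an expected step of a 1.3-fold higher number from compound 2 to compound 4 (0.10 log units; within the scatter).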

Compound 4, dissociation constant: 20 nM
The estimate for compound 4 equals the measured number at the digits printed; measured number inside the range.
By their numbers in this assay, from the lowest: compounds 1, 2, 4 and 3 (each within the scatter of the next, the first and the last beyond it).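

In this assay, the change from carbamoyl to hydroxy takes the group at this aromatic carbon from 3 heavy atoms to 1 heavy atom, with no ring in either group and the same count of hydrogen-bond donors and acceptors, and gives a 1.3-fold higher number from compound 2 to compound 4 (0.10 log units; within the scatter). At this place, ortho to a large group, the carbonyl and nitrogen of carbamoyl can therefore go without a change that can be told from the scatter, so these atoms are not needed to hold the value of compound 2 at this level. Hydroxy is less clearly separated from hydrogen than hydroxymethyl is, since compound 4 at 20 nM lies within the scatter of compound 3 at 39.8 nM, while compound 1 lies beyond it; no independent measurement here accounts for any of these values.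

Going by these compounds, what a methoxy group, an amine or a carboxylic acid would give at this place remains open. Without such groups, the shared hydrogen-bond counts of the carbamoyl and hydroxy groups cannot be tied to the values seen in this series.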